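Sulfonyl aryl swap on the shared core

The compounds below may be only part of what the source reports. "The series", "measured", "known", "first", "only" and "open" are said of these compounds alone.

The shared core, seen in compound 1 `CC(=O)N(C)c1ccc2[nH]c(-c3n[nH]c4ccccc34)cc2n1`, carries a methylated nitrogen on an aromatic ring that bears an acyl or sulfonyl group. In a functional assay on HL-60 cells (Homo sapiens) for antiproliferative activity, read by MTT assay, with a stated time of 72 h (on this read-out lower numbers stand for stronger inhibition and higher numbers for weaker inhibition), compound 1 gives 5110 nM. Compound 2 `CN(C(=O)c1ccccc1)c1ccc2[nH]c(-c3n[nH]c4ccccc34)cc2n1` gives 4850 nM in this assay; the step of a 1.1-fold lower number from compound 1 to compound 2 (0.02 log units; within the scatter) is within the scatter. Compound 3 `CN(c1ccc2[nH]c(-c3n[nH]c4ccccc34)cc2n1)S(=O)(=O)c1ccc(Cl)cc1` gives 770 nM in this assay, the lowest of the three numbers, with the steps of a 6.6-fold lower number from compound 1 to compound 3 (0.82 log units; beyond the scatter) and a 6.3-fold lower number from compound 2 to compound 3 (0.80 log units; beyond the scatter) both beyond the scatter.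

Compound 4 `COc1ccc(OC)c(S(=O)(=O)N(C)c2ccc3[nH]c(-c4n[nH]c5ccccc45)cc3n2)c1` differs from compound 3 in one place: 2,5-dimethoxyphenyl in place of 4-chlorophenyl on a sulfonyl sulfur. Neither measured step bears directly on this change; both concern the exchange of an acyl group for the sulfonyl group, and the aryl on the sulfonyl sulfur has not varied among the measured compounds. With nothing in the measured steps to indicate a direction, the expectation for compound 4 in this assay is a step of a 1.2-fold higher number from compound 3 to compound 4 (0.07 log units; within the scatter), not beyond the scatter. Compound 4 is therefore estimated at 900 nM in this assay, with a range from 300 nM to 2700 nM. The measured compounds offer no variation of the aryl on the sulfonyl sulfur, so the range is kept wide.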

Compound 4, half-maximal inhibitory concentration: 840 nM
Compound 4: the middle estimate sits 1.1-fold (0.03 log units) above what was measured; measured number inside the range.
By their numbers in this assay, from the lowest: compounds 3 and 4 (each within the scatter of the next); then compounds 2 and 1 (each within the scatter of the next).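

On the aryl carried by the sulfonyl sulfur, the exchange of 4-chlorophenyl for 2,5-dimethoxyphenyl gives a 1.1-fold higher number from compound 3 to compound 4 (0.04 log units; within the scatter) in this assay, so the two groups cannot be told apart on this read-out. This is the first variation at this position among the compounds shown, and the step stays within the scatter although the groups differ clearly in composition: the entering group has 10 heavy atoms, 2 hydrogen-bond acceptors and no chlorine, and the leaving group has 7 heavy atoms and 0 hydrogen-bond acceptors. No available evidence accounts for the level result across this change.

Going by these compounds, two aryl groups cannot settle whether this position tolerates change in general, so the effect of an unsubstituted phenyl, a pyridine ring, an aryl bearing an amine or a carboxylic acid, or a plain alkyl chain on the sulfonyl sulfur remains open. The methyl on the sulfonamide nitrogen stays the same throughout, which also leaves open what a hydrogen or an ethyl group would do there.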